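The source may hold more compounds than are shown below. What is called first, only, known or untested is meant among the compounds shown, and "the series" means these compounds.

Three compounds were tested in an ADME assay on MT4 cells (Homo sapiens) for cytotoxicity, read by MTT assay, with a stated time of 4 days; on this read-out lower numbers stand for higher toxicity in this test and higher numbers for lower toxicity in this test. Compound 1 `CC1CCCCN1c1nc(Cc2c(F)cccc2F)cc(=O)[nH]1` gives a value that is only a limit of the assay, > 78000 nM. Compound 2 `CC1CCCN(c2nc(Cc3c(F)cccc3F)cc(=O)[nH]2)C1` likewise returns only a limit, > 78000 nM. For the measured compounds named here, compound 3 `Cc1c(Cc2c(F)cccc2F)nc(N2CCCCC2C)[nH]c1=O` gives the one true number of the set, 75000 nM in this assay. Compound 3 differs from compound 1 by methyl in place of hydrogen on an aromatic carbon, and the step is an at least 1.0-fold lower number from compound 1 to compound 3 (0.01 log units; that floor lies within the scatter). Compound 2 differs from compound 1 by 3-methylpiperidin-1-yl in place of 2-methylpiperidin-1-yl on an aromatic carbon, and the step here is a step that the two limits leave unreadable from compound 1 to compound 2, because of the limit of > 78000 nM in this assay, at which 2 of the 3 values shown sit.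

Compound 4 `Cc1c(Cc2c(F)cccc2F)nc(N2CCCC(C)C2)[nH]c1=O` has not yet been measured. It stands to compound 3 as compound 2 stands to compound 1: 3-methylpiperidin-1-yl in place of 2-methylpiperidin-1-yl on an aromatic carbon. The surroundings are not quite the same, since in compound 3 the changed position is also para to a methyl group, so this is the same kind of change rather than the same change. Since compound 2 in this assay gives > 78000 nM and compound 3 gives 75000 nM, the step from compound 3 to compound 4 is expected to be a 1.0-fold higher number from compound 3 to compound 4 (0.02 log units; within the scatter). Compound 4 is therefore estimated at 78000 nM, between 40000 nM and 160000 nM, most likely reported again as a limit.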

Compound 4, half-maximal cytotoxic concentration: > 75000 nM
Compound 4 ended at the assay's limit (the forecaster's own chance of this, stated with the estimate: 60%); the middle value does not contradict the limit.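

Carrying 3-methylpiperidin-1-yl in place of 2-methylpiperidin-1-yl onto the core of compound 3 gives, in this assay, a number no lower from compound 3 to compound 4 (the limit leaves the size open). The same kind of change on the core of compound 1 cannot be read, and neither can the step that adds the methyl group to compound 2, because these pairs rest on limits alone: the limit of > 78000 nM in this assay, at which 2 of the 4 values shown sit. So the new result shows that the change gave no lower number on the methylated core, which sits well with the limits seen on the core of compound 1, but it does not show that the step has the same size on the two cores, or what size it has on either.

From the compounds shown here alone, whether piperidin-1-yl without a methyl group, 4-methylpiperidin-1-yl or morpholin-4-yl at this place would also reach a limit in this assay stays open. So does what an ethyl group in place of the methyl group on the core would do to the number.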